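Swapping chloro for fluoro on a second core

A few compounds are considered here, and "the series" means these few. Any claim that something is new, unique, unknown or untested is made for them only; others in the source may bear on it.

Measured compounds:
compound 1 `Cc1cc(C)c2c(O)cc(-c3cccc(F)c3)nc2n1` gives 5620 nM in a functional assay on cells (Tumor Cell line, Homo sapiens) for inhibition; on this read-out lower numbers stand for stronger inhibition of growth and higher numbers for weaker inhibition of growth
compound 2 `Cc1cc(C)c2c(O)cc(-c3cccc(Cl)c3)nc2n1` gives 26300 nM in this assay
compound 3 `Cc1cnc2[nH]c(-c3cccc(Cl)c3)cc(=O)c2c1` gives 30900 nM in this assay

Compounds 1 and 2 share one core and compound 3 carries another; the difference between the two cores is not broken down here. Within the first pair the only change is fluoro in place of chloro on an aromatic carbon, and this single change moved the read-out by a 4.7-fold lower number from compound 2 to compound 1 (0.67 log units; beyond the scatter), a step beyond the scatter. Compound 3 stands with the highest number of the three, yet its gap to compound 2 is within the scatter, so no order between those two can be claimed; only against compound 1 is compound 3 clearly weaker.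

Compound 4 `Cc1cnc2[nH]c(-c3cccc(F)c3)cc(=O)c2c1` has not been measured. For the measured compounds named here, it is related to compound 3 by fluoro in place of chloro on an aromatic carbon, which is the same kind of change as the one from compound 2 to compound 1, on the same place, but now on the other core. Whether the second core answers the swap in the same way is not known from anything measured here. On the strength of the step already seen, compound 4 is expected to come in lower than compound 3 by about a 3.6-fold lower number from compound 3 to compound 4 (0.56 log units; beyond the scatter) in this assay, with the reservation that the step may not carry over in full because a 4.7-fold lower number from compound 2 to compound 1 (0.67 log units; beyond the scatter) was seen only once and on a different core. The estimated value for compound 4 is 8500 nM, within a range from 3000 nM to 25000 nM.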

Compound 4, concentration for total growth inhibition: 5130 nM
Estimate against measurement, compound 4: 1.7-fold (0.22 log units) above; the measured number falls inside the stated range.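

In this assay the swap of chloro for fluoro on the second core gave a 6.0-fold lower number from compound 3 to compound 4 (0.78 log units; beyond the scatter) and so pointed the same way as on the first core, where compound 1 carries fluoro and compound 2 chloro. The size of the step also held from one core to the other, and the two steps cannot be told apart: the same change on two cores in this assay, a 4.7-fold lower number (0.67 log units; beyond the scatter) from compound 2 to compound 1 and a 6.0-fold lower number (0.78 log units; beyond the scatter) from compound 3 to compound 4, 1.3-fold (0.11 log units) apart, within the scatter of two such steps. This shows that, in this series and in this read-out, the change carried over from the core of compound 2 to the core of compound 3 in both direction and size, but it rests on just two pairs, a single place on the aromatic ring and one cell-based read-out, so it neither sets a rule for other cores nor explains why the fluoro compounds give the lower numbers.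

From the compounds shown here alone, what a methoxy group, a nitrile or an amine in the same place would do on either core remains open, as does whether such a group would follow the same trend on both cores. Also open is what the separate parts of the difference between the two cores contribute, since no pair shown isolates any one of them.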